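Bromo to Chloro on the Aryl Piperazine Sulfonamide

A few compounds are considered here, and "the series" means these few. Any claim that something is new, unique, unknown or untested is made for them only; others in the source may bear on it.

Compound 2 `CCCn1c(=O)[nH]c2nc(-c3ccc(S(=O)(=O)N4CCN(C)CC4)cc3)[nH]c2c1=O` carries a methyl on the amine nitrogen of the ring and gives 334 nM in an assay on CHO cells for displacement of a labelled ligand from adenosine receptor A1 (Homo sapiens), read by scintillation counting, with a stated time of 90 min, in the presence of a further agent that is not named here; on this read-out lower numbers stand for stronger inhibition and higher numbers for weaker inhibition. Compound 3 `CCCn1c(=O)[nH]c2nc(-c3ccc(S(=O)(=O)N4CCN(c5ccccc5Br)CC4)cc3)[nH]c2c1=O` replaces that methyl with a 2-bromophenyl. In this assay compound 3 returns only a limit, > 1000 nM. The change is recorded as an at least 2.9-fold higher number from compound 2 to compound 3 (0.47 log units; beyond the scatter), a bound rather than a measured size. Compound 1 `CCCn1c(=O)c2[nH]c(-c3ccc(S(=O)(=O)N4CCN(c5ccc(Cl)cc5)CC4)cc3)nc2n(CC)c1=O`, which bears a 4-chlorophenyl on the same nitrogen and a differently substituted core, also returns only a limit in this assay, > 1000 nM. Compound 3 thus sits at the limit of > 1000 nM in this assay, at which 2 of the 3 values shown sit.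

Compound 4 `CCCn1c(=O)[nH]c2nc(-c3ccc(S(=O)(=O)N4CCN(c5ccccc5Cl)CC4)cc3)[nH]c2c1=O` differs from compound 3 by chloro in place of bromo on an aromatic carbon. Among the measured compounds shown here, none of the measured steps covers this halogen exchange; the one step recorded, an at least 2.9-fold higher number from compound 2 to compound 3 (0.47 log units; beyond the scatter), concerns a larger change and is itself cut off by the limit. Because the limit of > 1000 nM in this assay, at which 2 of the 3 values shown sit, holds for both aryl-substituted compounds, compound 4 is expected to remain weak, with a step that the limit leaves unreadable from compound 3 to compound 4 that is expected to lie within the scatter. Compound 4 is therefore estimated at 2000 nM in this assay, in the range 800 nM to 6000 nM.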

Compound 4, inhibition constant: > 1000 nM
Compound 4 ended at the assay's limit; the forecaster's own chance of this, stated with the estimate: 75%; the middle value lies beyond the limit too.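

In this assay compound 4 gives > 1000 nM, which is a limit of the assay and not a number. Placing 2-chlorophenyl instead of methyl on the amine nitrogen in the ring gives an at least 2.9-fold higher number from compound 2 to compound 4 (0.47 log units; beyond the scatter), so the weakening seen with 2-bromophenyl on this nitrogen also appears when chloro takes the place of bromo on the aromatic carbon. The step between the two halogens cannot be read, and any difference between them stays hidden in this assay: the limit of > 1000 nM in this assay, at which 3 of the 4 values shown sit.

On these data alone, how weak compound 3 and compound 4 really are remains open. So does what a benzyl group or a longer alkyl chain on this nitrogen, or a fluoro in place of the chloro on the phenyl ring, would give in this assay.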